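Topoisomerase series: swapping the benzyl aryl on compound 2

This account rests on a few compounds, and the source may have more. Where it says the series, first, only, none or still open, it means among the compounds named here.

Two compounds of this series have numbers in an assay on isolated protein for inhibition of DNA topoisomerase 1 (Homo sapiens), with a stated time of 15 min; on this read-out higher numbers stand for weaker inhibition and lower numbers for stronger inhibition. Compound 1 `O=C(O)c1cn(Cc2ccc(-n3cccn3)cc2)c2cc(NC[C@@H]3CCNC3)c(F)cc2c1=O` gives 200000 nM. Compound 2 `NC[C@@H]1CCN(c2cc3c(cc2F)c(=O)c(C(=O)O)cn3Cc2cc(-c3ccccc3)no2)C1` gives 58300 nM, the lower of the two numbers; the gap to compound 1 lies beyond the scatter, so compound 2 stands as the stronger inhibitor of the pair. The two differ in more than one place, so no single change can be read from that gap.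

Compound 3 `NC[C@@H]1CCN(c2cc3c(cc2F)c(=O)c(C(=O)O)cn3Cc2ccc(-n3cccn3)cc2)C1` is not yet measured. It differs from compound 2 by 4-(1H-pyrazol-1-yl)phenyl in place of 3-phenyl-1,2-oxazol-5-yl on a saturated chain carbon bound to an aromatic nitrogen. The group that enters is the one carried by compound 1, whose number is the higher of the two shown, but compound 1 also carries a different amine side chain, so that number only hints at the direction. The expectation is a weakening step from compound 2 to compound 3 of about a 1.9-fold higher number from compound 2 to compound 3 (0.28 log units; within the scatter), somewhat beyond the scatter. Compound 3 is therefore estimated at 110000 nM, with a plausible range from 30000 nM to 400000 nM.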

Compound 3, half-maximal inhibitory concentration: 91600 nM
Compound 3: middle estimate off by 1.2-fold (0.08 log units), on the high side; measured number inside the range.
By their numbers in this assay, from the lowest: compounds 2 and 3 (each within the scatter of the next); then compound 1.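

In this assay, 4-(1H-pyrazol-1-yl)phenyl in place of 3-phenyl-1,2-oxazol-5-yl on a saturated chain carbon bound to an aromatic nitrogen gives a 1.6-fold higher number from compound 2 to compound 3 (0.20 log units; within the scatter), so this exchange of two groups, each made up of a five-membered and a six-membered aromatic ring, does not separate the compounds on this read-out. Among these compounds, with 4-(1H-pyrazol-1-yl)phenyl held fixed, 3-(aminomethyl)pyrrolidin-1-yl in place of ((pyrrolidin-3-yl)methyl)amino on an aromatic carbon gives a 2.2-fold lower number from compound 1 to compound 3 (0.34 log units; beyond the scatter), a modest step towards stronger inhibition and the first single change that can be read beyond the scatter. No measured evidence is available to explain the size of either step.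

It remains open whether the amine step carries over to compounds bearing 3-phenyl-1,2-oxazol-5-yl, as only one pair with that change is shown. Also open, as far as these compounds go, is whether a simple benzyl-free group at the first position, such as a plain ethyl chain or a longer alkyl chain, or an open-chain amine such as dimethylamino on the aromatic carbon, would shift the number beyond the scatter.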